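Swapping dimethylamino for cyano on the anilino ring

The source may report more compounds than this note shows. Statements on the series, on what has been measured and on what is new or still open speak of the compounds shown alone.

Compound 1 `COc1cc(OC)cc(Oc2ncccc2-c2n[nH]c(Nc3ccc4c(c3)OCCO4)n2)c1`: 89%
Compound 2 `COc1cc(OC)cc(Oc2ncccc2-c2n[nH]c(Nc3ccc(N(C)C)cc3)n2)c1`: 86%

Both compounds share one core and differ only in the group carried on a nitrogen attached to an aromatic ring. In a functional assay on A-431 cells (Homo sapiens), tested at 0.1 uM (a lower number here means less inhibition, a higher number more inhibition at the concentration tested (going by the name of the read-out)), compound 1 gives 89%, and compound 2 gives 86%, the lowest of the two numbers, though the step of a number 3 percentage points lower from compound 1 to compound 2 (within the scatter) lies within the scatter, so the two cannot be told apart.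

Compound 3 `COc1cc(OC)cc(Oc2ncccc2-c2n[nH]c(Nc3ccc(C#N)cc3)n2)c1` is not yet measured. It differs from compound 2 by cyano in place of dimethylamino on an aromatic carbon. Going by the values given here, no measured pair changes this group, so only the step of a number 3 percentage points lower from compound 1 to compound 2 (within the scatter), which replaced the whole ring system on that nitrogen without moving the number beyond the scatter, gives a hint: the change made so far at this position left the number level.

Compound 3 is therefore expected to stay close to compound 2, with an estimated step of a number 6 percentage points lower from compound 2 to compound 3 (within the scatter), giving an estimate of 80% in this assay, likely between 60% and 93%.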

Compound 3, a percentage reported as inhibition, at one concentration (the size of the read-out at that concentration, not a potency): 27%
The estimate for compound 3 lay 53 percentage points above the measured number; the measured number lies below the stated range.
By their numbers in this assay, from the lowest: compound 3; then compounds 2 and 1 (each within the scatter of the next).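

The ring on this nitrogen is not indifferent to what it carries, even though compound 1 and compound 2 gave no sign of that. In this assay cyano in place of dimethylamino gives a number 59 percentage points lower from compound 2 to compound 3 (beyond the scatter) from a swap of one small group on an aromatic carbon, para to a large group. The 4-cyanophenyl group in place of the 2,3-dihydro-1,4-benzodioxin-6-yl group gives a similar picture, with a number 62 percentage points lower from compound 1 to compound 3 (beyond the scatter) on the same shared core. No measurement available here bears on the reason for this drop.

Going by these compounds alone, with only three compounds, it remains open whether the low number belongs to cyano alone or is shared by other groups at this place. A methoxy group, a chlorine atom or a carboxylic acid there would begin to separate these possibilities.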